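Aryl amide change from compound 3 to compound 4

This account rests on a few compounds, and the source may have more. Where it says the series, first, only, none or still open, it means among the compounds named here.

Measured so far in an ADME assay on MRC5 cells (Homo sapiens) for inhibition, with a stated time of 72 h; a lower number here means that less compound is needed, a higher number that more compound is needed for the effect:
compound 1 `CO[C@H]1CC[C@H](NC(=O)c2n[nH]cc2NC(=O)c2ccc(F)cc2F)CC1`, compound 1 gives 11000 nM
compound 2 `CO[C@H]1CC[C@H](NC(=O)c2n[nH]cc2NC(=O)c2ccccc2C(F)(F)F)CC1`, compound 2 gives 3300 nM
compound 3 `CO[C@H]1CC[C@H](NC(=O)c2n[nH]cc2NC(=O)c2cc3ccccc3o2)CC1`, compound 3 gives 800 nM

Compound 3 holds the lowest number of the three; compound 2 stands above it and compound 1 highest, both beyond the scatter.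

Compound 4 `CO[C@H]1CC[C@H](NC(=O)c2n[nH]cc2NC(=O)c2ccccc2F)CC1` is next: 2-fluorophenyl in place of 1-benzofuran-2-yl on a carbonyl carbon. Within the data shown here, the only step that bears on it is a 14-fold lower number from compound 1 to compound 3 (1.14 log units; beyond the scatter), a large fall when 1-benzofuran-2-yl replaced 2,4-difluorophenyl on that carbonyl carbon. Compound 4 carries 2-fluorophenyl at the same carbonyl carbon, so the change runs the other way, and most of that fall is expected to be given back, though compound 4 need not reach the number of compound 1.

For compound 4 the expected step is an 8.8-fold higher number from compound 3 to compound 4 (0.94 log units; beyond the scatter), a rise beyond the scatter. Compound 4 is estimated at 7000 nM, within 2500 nM to 20000 nM.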

Compound 4, half-maximal effective concentration: 1000 nM
Compound 4: middle estimate off by 7.0-fold (0.85 log units), on the high side; the whole stated range lies above it.
By their numbers in this assay, from the lowest: compounds 3 and 4 (each within the scatter of the next); then compound 2; then compound 1.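

In this assay, the fused 1-benzofuran-2-yl is not required on this carbonyl carbon: the single-ring 2-fluorophenyl gives a 1.3-fold higher number from compound 3 to compound 4 (0.10 log units; within the scatter). Within the phenyl amides, the substituents carry large weight, with hydrogen in place of fluoro giving an 11-fold lower number from compound 1 to compound 4 (1.04 log units; beyond the scatter) and fluoro in place of trifluoromethyl giving a 3.3-fold lower number from compound 2 to compound 4 (0.52 log units; beyond the scatter). No measured evidence accounts for these steps.

On these data alone, whether a nitrile, methoxy or amine in place of the fluoro of compound 4 would shift the number remains open. So does the outcome with a non-aromatic group such as cyclohexyl on the carbonyl carbon.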